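Selenocyanate for thiocyanate on two cores

The source may report more compounds than this note shows. Statements on the series, on what has been measured and on what is new or still open speak of the compounds shown alone.

Compound 1 `N#CSCN1C(=O)c2ccccc2C1=O` and compound 2 `N#C[Se]CN1C(=O)c2ccccc2C1=O` share one core; compound 3 `Cc1noc(C)c1CSC#N` and compound 4 `Cc1noc(C)c1C[Se]C#N` share another, and the difference between the two cores is not broken down here. In a functional assay on MCF7 cells (Homo sapiens) for cytotoxicity, read by MTT assay, with a stated time of 72 h (on this read-out higher numbers stand for weaker inhibition of growth and lower numbers for stronger inhibition of growth), compound 1 reaches a limit of the assay, > 100000 nM. That value is the limit of > 100000 nM in this assay, at which 1 of the 3 values shown sits. In this assay compound 2 gives 56100 nM. The change is a group of 3 heavy atoms (1 carbon, 1 nitrogen, 1 selenium; no ring) in place of a group of 3 heavy atoms (1 carbon, 1 nitrogen, 1 sulfur; no ring), on a saturated chain carbon bound to an amide-type nitrogen in a ring, and the step is an at least 1.7-fold lower number from compound 1 to compound 2 (0.25 log units; that floor lies within the scatter). In this assay compound 3 gives 44600 nM. Compound 4 carries the same kind of change, (a group of 3 heavy atoms (1 carbon, 1 nitrogen, 1 selenium; no ring) in place of a group of 3 heavy atoms (1 carbon, 1 nitrogen, 1 sulfur; no ring), on a saturated chain carbon bound to an aromatic carbon); the place differs, a saturated chain carbon bound to an aromatic carbon rather than one bound to an amide-type nitrogen in a ring. The step from compound 3 to compound 4 in this assay is expected to be a 1.5-fold lower number from compound 3 to compound 4 (0.17 log units; within the scatter), resting on an at least 1.7-fold lower number from compound 1 to compound 2 (0.25 log units; that floor lies within the scatter), whose floor lies within the scatter. Compound 4 is estimated at 30000 nM in this assay, expected between 12000 nM and 75000 nM.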

Compound 4, concentration for total growth inhibition: 8300 nM
For compound 4 the middle estimate is 3.6-fold (0.56 log units) above the measured one, and the stated range ends above it.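

Selenocyanate in place of thiocyanate, on a saturated chain carbon bound to an aromatic carbon, gives a 5.4-fold lower number from compound 3 to compound 4 (0.73 log units; beyond the scatter) in this assay. Whether a step of that size carries from one core to the other remains unsettled: the same change on two cores in this assay, an at least 1.7-fold lower number (0.25 log units; that floor lies within the scatter) from compound 1 to compound 2 and a 5.4-fold lower number (0.73 log units; beyond the scatter) from compound 3 to compound 4; the limit leaves it open whether they differ. The value of compound 1, > 100000 nM, is a limit of the assay and not a number.

The compounds shown leave open whether the step would hold on a third core, since two cores give no general rule for the series. Also open, on these data alone, is how a longer chain in place of the saturated chain carbon, or an amine or a carboxylic acid on either core, would alter the step.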